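Cyclic Sulfonamide Returns After Benzyl(methyl)amino Loss

The compounds below may be only part of what the source reports. "The series", "measured", "known", "first", "only" and "open" are said of these compounds alone.

Compound 2 `CCOC(=O)[C@@H]1CCCN(S(=O)(=O)c2ccc(S(=O)(=O)N(C)Cc3ccccc3)cc2)C1` gives in a functional assay on MIA PaCa-2 cells (Homo sapiens) for inhibition, read by MTT assay, with a stated time of 7 days (a lower number here means a stronger inhibitor, a higher number a weaker inhibitor), only a limit, > 30000 nM. Compound 1 `CCOC(=O)[C@@H]1CCCN(S(=O)(=O)c2ccc(S(=O)(=O)N3CCCCC3)cc2)C1` gives in this assay 2900 nM, and compound 3 `CCOC(=O)[C@@H]1CCCN(S(=O)(=O)c2ccc(S(=O)(=O)N(CC)CC)cc2C)C1` gives 5100 nM. Within the data shown here, the one measured change at this sulfonyl sulfur is the step of an at least 10-fold higher number from compound 1 to compound 2 (1.01 log units; beyond the scatter), whose size rests on (the limit of > 30000 nM in this assay, at which 1 of the 3 values shown sits). Compound 4 `CCOC(=O)[C@@H]1CCCN(S(=O)(=O)c2ccc(S(=O)(=O)N3CCOCC3)cc2)C1` carries morpholin-4-yl in place of benzyl(methyl)amino on a sulfonyl sulfur. Given compound 1 at 2900 nM with its six-membered piperidin-1-yl ring, the return from the open benzyl(methyl)amino group to another six-membered ring, morpholin-4-yl, is expected to recover much of that loss, so the step of an at least 6.6-fold lower number from compound 2 to compound 4 (0.82 log units; beyond the scatter) is expected. Compound 4 is therefore estimated at 4500 nM, with a range from 1500 nM to 15000 nM.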

Compound 4, half-maximal inhibitory concentration: 23500 nM
For compound 4 the middle estimate is 5.2-fold (0.72 log units) below the measured one; the measured number lies above the stated range.
By their numbers in this assay, from the lowest: compounds 1 and 3 (each within the scatter of the next); then compound 4. At a limit, above all of these: compound 2.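

In this assay, a six-membered ring on this sulfonyl sulfur is not enough by itself: morpholin-4-yl in place of piperidin-1-yl gives an 8.1-fold higher number from compound 1 to compound 4 (0.91 log units; beyond the scatter). Morpholin-4-yl in place of benzyl(methyl)amino gives an at least 1.2-fold lower number from compound 2 to compound 4 (0.10 log units; that floor lies within the scatter), so no gain over the open group can be claimed. That step rests on a limit: the limit of > 30000 nM in this assay, at which 1 of the 4 values shown sits.

The compounds shown leave open whether a pyrrolidin-1-yl or a piperazin-1-yl group on this sulfur would stand nearer to piperidin-1-yl or to morpholin-4-yl.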